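Nitrophenyl carbamoyl to thiocarbamoyl on the piperazine nitrogen

The compounds below may be only part of what the source reports. "The series", "measured", "known", "first", "only" and "open" are said of these compounds alone.

Measured so far:
compound 1, `COc1ccc(Oc2ccccc2-c2ccsc2S(=O)(=O)N2CCN(C(=O)Nc3ccc([N+](=O)[O-])cc3)CC2)cc1OC`, 17%
compound 2, `O=C(Nc1cccc([N+](=O)[O-])c1)N1CCN(S(=O)(=O)c2sccc2-c2ccccc2Oc2ccc(O)c(O)c2)CC1`, 30%

Both compounds were run in an assay for binding affinity to Apoptosis regulator Bcl-2 (Homo sapiens), read by fluorescence polarization, with stated times of 30 min and 20 min, tested at 100 uM; a higher number here means more inhibition at the concentration tested (going by the name of the read-out), a lower number less inhibition. Compound 2 stands highest of the two numbers; the nearest is compound 1, whose value lies lower, a gap beyond the scatter. Going by the values given here, no step between compounds that differ in only one place is available, so the effect of the change below is not anchored by any measured pair.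

Compound 3, `O=[N+]([O-])c1ccc(NC(=S)N2CCN(S(=O)(=O)c3sccc3-c3ccccc3Oc3ccc(O)c(O)c3)CC2)cc1`, is not yet measured. It differs from compound 2 as follows: a group of 12 heavy atoms (7 carbon, 2 nitrogen, 2 oxygen, 1 sulfur; one six-membered aromatic ring of carbon only) in place of a group of 12 heavy atoms (7 carbon, 2 nitrogen, 3 oxygen; one six-membered aromatic ring of carbon only), on an amine nitrogen in a ring. The leaving (3-nitrophenyl)carbamoyl group and the entering group are matched in size and in donor and acceptor count; one oxygen is exchanged for one sulfur.

Among the compounds with values here, with no comparable step in hand, the expected step of a number 2 percentage points lower from compound 2 to compound 3 (within the scatter) is small, with no sure direction, and likely within the scatter. Compound 3 is therefore estimated at 28%, with a range from 10% to 48%.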

Compound 3, a percentage reported as inhibition, at one concentration (the size of the read-out at that concentration, not a potency): 31%
Compound 3: the middle estimate sits 3 percentage points below what was measured; the measured number falls inside the stated range.
By their numbers in this assay, from the lowest: compound 1; then compounds 2 and 3 (each within the scatter of the next).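

Working note on the piperazine nitrogen position: in this assay, the first readable step at this position is a number 1 percentage points higher from compound 2 to compound 3 (within the scatter), so compound 2 and compound 3 cannot be told apart in this read-out. On this pair, exchanging the (3-nitrophenyl)carbamoyl group for the entering group, with one sulfur in place of one oxygen and the nitro group at a different ring position, is accommodated on the shared core, although the two differences are read only together. No supporting measurement bears on why the step is small.

Going by these compounds, the separate contributions of the sulfur exchange and the nitro placement remain open. Also open, on these data alone, is how this position would respond to a group of a different kind, such as a carboxylic acid or an amine in place of the nitro group on the aromatic ring.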